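Cytotoxicity notes: isopropyl to cyclopentyl on a sulfur

This account rests on a few compounds, and the source may have more. Where it says the series, first, only, none or still open, it means among the compounds named here.

Measured so far in a functional assay on MT4 cells (Homo sapiens) for cytotoxicity; on this read-out higher numbers stand for lower toxicity in this test and lower numbers for higher toxicity in this test
compound 1 (`CCC(c1ccccc1)c1cc(O)nc(SC2CCCC2)n1`) gives 50000 nM
compound 2 (`CCC(c1cc(O)nc(SC(C)C)n1)c1c(F)cccc1F`) gives 130000 nM

Compound 2 holds the higher of the two numbers, and its gap to compound 1 lies beyond the scatter. Going from compound 2 to compound 3 (`CCC(c1cc(O)nc(SC2CCCC2)n1)c1c(F)cccc1F`) is cyclopentyl in place of isopropyl on a sulfur. Among the measured compounds shown here, no measured pair shows this change alone. For the measured compounds named here, compound 1 also carries cyclopentyl on a sulfur and gives 50000 nM as the only guide. In this assay a modest fall is expected, estimated as a 2.2-fold lower number from compound 2 to compound 3 (0.34 log units; beyond the scatter) and so just beyond the scatter. The estimate for compound 3 is 60000 nM (expected range 20000 nM to 150000 nM).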

Compound 3, half-maximal cytotoxic concentration: > 200000 nM
Compound 3 gave a limit, no number (the forecaster's own chance of this, stated with the estimate: 15%); middle value at least 3.3-fold (0.52 log units) from the limit.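

In this assay compound 3 gives a limit, not a number: the limit of > 200000 nM in this assay, at which 1 of the 3 values shown sits. Cyclopentyl in place of isopropyl on a sulfur gives an at least 1.5-fold higher number from compound 2 to compound 3 (0.18 log units; that floor lies within the scatter), so this change shows no fall in this test, and the size of any rise stays unfixed. With cyclopentyl held constant, 2,6-difluorophenyl in place of phenyl gives an at least 4.0-fold higher number from compound 1 to compound 3 (0.60 log units; beyond the scatter), pointing to lower toxicity in this test.

From the compounds shown here alone, how a longer chain or a carboxylic acid on the sulfur would read stays open. Going by these compounds, whether the 2,6-difluorophenyl step holds with isopropyl on the sulfur also stays open.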